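The source may report more compounds than this note shows. Statements on the series, on what has been measured and on what is new or still open speak of the compounds shown alone.

Measured compounds:
compound 1 `CCCCCCCCCCCC[C@@H](O)[C@H]1CC[C@H]([C@H](O)CCCCCCCCCCNC(=O)c2ccsc2)O1`: 1700 nM
compound 2 `CCCCCCCCCCCC[C@@H](O)[C@H]1CC[C@H]([C@H](O)CCCCCCCCCCNC(=O)c2ccnn2C)O1`: 22900 nM
compound 3 `CCCCCCCCCCCC[C@@H](O)[C@H]1CC[C@H]([C@H](O)CCCCCCCCCCNC(=O)c2cccs2)O1`: 1820 nM

In a functional assay on OVCAR-4 cells (Homo sapiens) for inhibition, read by colorimetric assay and sulforhodamine B assay, with a stated time of 48 h (on this read-out higher numbers stand for weaker inhibition of growth and lower numbers for stronger inhibition of growth), compound 1 gives the lowest of the three numbers. Compound 3 sits nearest to it, and the step of a 1.1-fold higher number from compound 1 to compound 3 (0.03 log units; within the scatter) lies within the scatter, so the two cannot be ranked against each other. Compound 2 sits furthest away, the step of a 13-fold higher number from compound 1 to compound 2 (1.13 log units; beyond the scatter) being a large one.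

Compound 4 `CCCCCCCCCCCC[C@@H](O)[C@H]1CC[C@H]([C@H](O)CCCCCCCCCCNC(=O)c2ccoc2)O1` has not been measured. Its change from compound 1 is furan-3-yl in place of thiophen-3-yl on a carbonyl carbon. For the measured compounds named here, two measured steps bear on this exchange of one five-membered aromatic ring for another on the carbonyl carbon: the step of a 1.1-fold higher number from compound 1 to compound 3 (0.03 log units; within the scatter), where one such ring replaced another without a change beyond the scatter, and the step of a 13-fold higher number from compound 1 to compound 2 (1.13 log units; beyond the scatter), where a ring of a different kind brought a large rise. The furan-3-yl ring in compound 4 is closer in kind to the thiophene rings of compounds 1 and 3 than to the pyrazole of compound 2, so for compound 4 the step of a 1.5-fold higher number from compound 1 to compound 4 (0.17 log units; within the scatter) is expected to stay within the scatter or be a small rise. Compound 4 is therefore estimated at 2500 nM, with a range from 900 nM to 7000 nM.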

Compound 4, concentration for 50% growth inhibition: 74100 nM
Compound 4: middle estimate off by 30-fold (1.47 log units), on the low side; measured number outside the range, above it.
By their numbers in this assay, from the lowest: compounds 1 and 3 (each within the scatter of the next); then compound 2; then compound 4.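

In this assay, oxygen in place of sulfur in the five-membered aromatic ring on the carbonyl carbon leaves the heavy-atom and hydrogen-bond counts unchanged, yet it gives a 44-fold higher number from compound 1 to compound 4 (1.64 log units; beyond the scatter) and, against the other thiophene, a 41-fold higher number from compound 3 to compound 4 (1.61 log units; beyond the scatter) on the same read-out. This position therefore does not treat all five-membered aromatic rings with one hetero atom alike, since the thiophen-3-yl and thiophen-2-yl rings cannot be ranked against each other while the furan-3-yl ring stands well apart from both. The furan-3-yl ring even gives a higher number than the 1-methyl-1H-pyrazol-5-yl ring, with a 3.2-fold higher number from compound 2 to compound 4 (0.51 log units; beyond the scatter) as a modest step.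

No evidence at hand accounts for the gap between the sulfur and oxygen rings. From the compounds shown here alone, it remains open whether a furan-2-yl ring would behave like furan-3-yl and whether a phenyl ring on this carbonyl carbon would stay level with the thiophenes.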